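A Dichlorophenyl Group Replaces Hydroxyphenyl at the Assay Limit

The source may report more compounds than this note shows. Statements on the series, on what has been measured and on what is new or still open speak of the compounds shown alone.

In a functional assay on U-251 cells (Homo sapiens) (on this read-out lower numbers stand for stronger inhibition of growth and higher numbers for weaker inhibition of growth), compound 3 (`O=S(=O)(/C=C/c1ccc(O)cc1)Cc1ccc(Nc2ncnc3ccc(Br)cc23)cc1`) reads > 100000 nM as a limit of the assay and not as a number. Compound 4 (`O=S(=O)(/C=C/c1ccc(Cl)cc1Cl)Cc1ccc(Nc2ncnc3ccc(Br)cc23)cc1`) differs from it in one place, with 2,4-dichlorophenyl in place of 4-hydroxyphenyl on a double-bonded chain carbon bound to a double-bonded chain carbon.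

Among the compounds with values here, one measured step bears on this change. Compound 2 (`O=S(=O)(/C=C/c1ccc(Br)cc1)Cc1ccc(Nc2ncnc3ccc(Br)cc23)cc1`) gives 11000 nM in this assay and shares its core with compound 3. Hydroxy in place of bromo on an aromatic carbon produced an at least 9.0-fold higher number from compound 2 to compound 3 (0.95 log units; beyond the scatter) in that pair, a step beyond the scatter. Compound 4 also gives up the hydroxy group, so a step of at least similar size in the opposite direction seems likely, toward stronger inhibition of growth.

Compound 1 (`O=S(=O)(/C=C/c1ccc(Cl)cc1Cl)Cc1ccc(Nc2ncnc3ccccc23)cc1`) gives 4000 nM in this assay with the same 2,4-dichlorophenyl group, although it lacks the bromo group carried by the other three compounds. The expected change is an at least 16-fold lower number from compound 3 to compound 4 (1.22 log units; beyond the scatter) on this evidence, well beyond the scatter. For compound 4 the estimated value is 6000 nM with an expected range from 1800 nM to 20000 nM in this read-out.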

Compound 4, concentration for 50% growth inhibition: 4000 nM
Compound 4: the middle estimate sits 1.5-fold (0.18 log units) above what was measured; measured number inside the range.
By their numbers in this assay, from the lowest: compounds 1 and 4 (each within the scatter of the next); then compound 2. At a limit, above all of these: compound 3.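

In this assay, the change at this place on the double-bonded chain carbon reads as an at least 25-fold lower number from compound 3 to compound 4 (1.39 log units; beyond the scatter), which ties the recovery of growth inhibition to 2,4-dichlorophenyl within the bromo-bearing series itself. Compound 3 stands at a limit of the assay, so the true size of that step remains unfixed: the limit of > 100000 nM in this assay, at which 1 of the 4 values shown sits. The new compound also shows that this place still responds when one halogen-bearing group replaces another, with a 2.8-fold lower number from compound 2 to compound 4 (0.44 log units; beyond the scatter), whereas bromo in place of hydrogen on an aromatic carbon of the shared core gives no change at the digits printed from compound 1 to compound 4 (within the scatter).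

The compounds shown leave open how a phenyl group carrying a methoxy group, an amine or a carboxylic acid would read at this place, and thus whether the weak end of the series belongs to hydroxy alone or extends to other such groups. The pair with and without bromo is shown only with 2,4-dichlorophenyl, so it remains open whether bromo on the aromatic carbon makes as little difference alongside 4-bromophenyl or 4-hydroxyphenyl.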